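This account rests on a few compounds, and the source may have more. Where it says the series, first, only, none or still open, it means among the compounds named here.

Measured so far:
- compound 1, `CN(c1ccc2cc(NC(=O)CCc3ccc(C(F)(F)F)cc3)ccc2n1)C1CCCC1`: in an assay on isolated protein for displacement of a labelled ligand from melanin-concentrating hormone receptor 1 (Homo sapiens) (a higher number here means a weaker inhibitor, a lower number a stronger inhibitor), compound 1 gives 2 nM
- compound 2, `O=C(CCCCCCCCCCCCc1ccc(C(F)(F)F)cc1)Nc1ccc2nc([N+]34CCC(CC3)CC4)ccc2c1`: in this assay compound 2 gives 5 nM

Of these two, compound 1 has the lower number, and its gap to compound 2 is beyond the usual scatter of repeated measurements, so compound 1 is the stronger inhibitor of the pair. Compound 3, `O=C(CCc1ccc(C(F)(F)F)cc1)Nc1ccc2nc(N3CC4CC3CO4)ccc2c1`, is not yet measured. It differs from compound 1 in one place: a group of 7 heavy atoms (5 carbon, 1 nitrogen, 1 oxygen; 2 five-membered non-aromatic rings with 1 hetero atom each) in place of a group of 7 heavy atoms (6 carbon, 1 nitrogen; one five-membered non-aromatic ring of carbon only), on an aromatic carbon. Going by the values given here, no pair of measured compounds differs in only this one place, so the size of this step has no direct precedent here; compounds 1 and 2 differ at several points at once and show only that a bicyclic amine on the shared core can sit alongside a low number. The step from compound 1 to compound 3 in this assay is therefore expected to be small, most likely a mild weakening, a 2.5-fold higher number from compound 1 to compound 3 (0.40 log units; beyond the scatter). Compound 3 is estimated at 5 nM, within a range of 1.5 nM to 20 nM.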

Compound 3, half-maximal inhibitory concentration: 13 nM
The estimate for compound 3 lay 2.6-fold (0.41 log units) below the measured number; low and high end bracket the measured number.
By their numbers in this assay, from the lowest: compound 1; then compound 2; then compound 3.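

In this assay, going by these compounds alone, the change on this aromatic carbon, next to the ring nitrogen, gives a 6.5-fold higher number from compound 1 to compound 3 (0.81 log units; beyond the scatter), the first direct reading of a single change at this position. The two groups have the same heavy-atom count, so the position responds to more than size alone: it distinguishes a single all-carbon ring on a methyl-bearing amine from a two-ring amine containing oxygen, although compound 3 still gives 13 nM. Nothing available here accounts for the size of this step.

This one step changes the ring count and swaps a carbon for oxygen together, so the contribution of each remains unresolved. Going by these compounds, how a simple pyrrolidine or morpholine at this position would compare with compound 1 and compound 3 also remains open.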